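The source may hold more compounds than are shown below. What is called first, only, known or untested is meant among the compounds shown, and "the series" means these compounds.

Working notes on the benzamide-capped aminoanilide series.

Three compounds have numbers in a functional assay on A2780 cells (Homo sapiens) for cytotoxicity, read by MTT assay, with a stated time of 72 h; on this read-out lower numbers stand for stronger inhibition and higher numbers for weaker inhibition. Compound 1 `Cc1cc(C)cc(CNC(=O)CN(CCCCCC(=O)Nc2ccccc2N)C(=O)c2cc(C)cc(C)c2)c1` gives 5100 nM, the lowest of the three numbers. Compound 2 `Nc1ccccc1NC(=O)c1ccc(CN(CC(=O)NCc2ccccc2)C(=O)c2cccnc2)cc1` gives 8900 nM, a number that sits within the usual scatter of that of compound 1, so no order between these two can be read. Compound 3 `CN(C)c1ccc(C(=O)N(CCCCCC(=O)Nc2cc(F)ccc2N)CC(=O)NCc2ccccc2)cc1` gives 25900 nM, which lies beyond the scatter from compound 1. Going by the values given here, no pair among the three differs in a single place, so none of these gaps can be tied to one structural change.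

Compound 4 `Cc1cc(C)cc(C(=O)N(CCCCCC(=O)Nc2ccccc2N)CC(=O)NCc2ccccc2)c1` is not yet measured. It is reached from compound 1 by one change: phenyl in place of 3,5-dimethylphenyl on a saturated chain carbon bound to an amide-type nitrogen. Both groups carry no hydrogen-bond donors or acceptors, and the change sits away from the aminoanilide end shared with compound 1. On the numbers at hand nothing points to a shift beyond the scatter, and the step from compound 1 to compound 4 is expected to be small, a 1.4-fold higher number from compound 1 to compound 4 (0.14 log units; within the scatter), if anything toward a slightly higher number. Compound 4 is accordingly estimated at 7000 nM, with a range from 3000 nM to 17000 nM in this assay.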

Compound 4, half-maximal inhibitory concentration: 20900 nM
Estimate against measurement, compound 4: 3.0-fold (0.48 log units) below; measured number above the stated range.
By their numbers in this assay, from the lowest: compounds 1 and 2 (each within the scatter of the next); then compounds 4 and 3 (each within the scatter of the next).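

Going by these compounds alone, the step of phenyl in place of 3,5-dimethylphenyl on a saturated chain carbon bound to an amide-type nitrogen is the first single-place comparison, and in this assay it reads a 4.1-fold higher number from compound 1 to compound 4 (0.61 log units; beyond the scatter) and lies beyond the scatter. This position is therefore not indifferent to the substitution of its ring: going from 8 to 6 heavy atoms here, with the rest of compound 1 kept, moves the number toward weaker inhibition. Nothing at hand bears on why the number moves.

Open, from the compounds shown here alone, is whether both methyl groups are needed, which a 3-methylphenyl at this position would address, and whether a 3,5-dichlorophenyl or 3,5-dimethoxyphenyl would serve equally. Also open, going by these compounds, is whether the same change on the other 3,5-dimethylphenyl, the one in the benzamide cap, gives a step of similar size.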